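Swapping a methylsulfanyl group for a benzylselanyl group on an isothiourea-type core

A few compounds are considered here, and "the series" means these few. Any claim that something is new, unique, unknown or untested is made for them only; others in the source may bear on it.

Compound 1 `CS/C(=N\C(=O)c1ccno1)NC(=O)c1ccno1`: > 100000 nM
Compound 2 `CS/C(=N\C(=O)c1cc2ccccc2s1)NC(=O)c1cc2ccccc2s1`: 15800 nM

Of the compounds shown here, two have been measured in a functional assay on HepG2 cells (Homo sapiens) for cytotoxicity, read by MTT assay, with a stated time of 72 h; a lower number here means a stronger inhibitor of growth, a higher number a weaker inhibitor of growth. Compound 1 `CS/C(=N\C(=O)c1ccno1)NC(=O)c1ccno1` gives > 100000 nM in this assay, and this is a limit of the assay rather than a number. Compound 2 `CS/C(=N\C(=O)c1cc2ccccc2s1)NC(=O)c1cc2ccccc2s1` carries two benzothiophene amide arms instead of the isoxazole amides of compound 1. In this assay compound 2 gives 15800 nM. Where compound 1 stands is therefore known only as a limit (the limit of > 100000 nM in this assay, at which 1 of the 2 values shown sits), so its exact position on the scale is open.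

The unmeasured compound 3 `O=C(/N=C(/NC(=O)c1ccno1)[Se]Cc1ccccc1)c1ccno1` keeps the isoxazole amides of compound 1 and changes one place: a group of 8 heavy atoms (7 carbon, 1 selenium; one six-membered aromatic ring of carbon only) in place of a group of 2 heavy atoms (1 carbon, 1 sulfur; no ring), on a carbon with a double bond to nitrogen. Going by the values given here, no pair of measured compounds shows this change, so its effect is not known from the data.

Compound 3 is expected to give 60000 nM in this assay, in the range 15000 nM to 300000 nM. The step this estimate implies, an at least 1.6-fold lower number from compound 1 to compound 3 (0.22 log units; that floor lies within the scatter), is expected to be modest at most, since compound 1 is known only as a limit (the limit of > 100000 nM in this assay, at which 1 of the 2 values shown sits).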

Compound 3, concentration for 50% growth inhibition: 9120 nM
Compound 3: middle estimate off by 6.6-fold (0.82 log units), on the high side; the whole stated range lies above it.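

In this assay, placing the benzylselanyl group on the carbon with a double bond to nitrogen, in place of methylsulfanyl and with the isoxazole amides kept, gives an at least 10-fold lower number from compound 1 to compound 3 (1.04 log units; beyond the scatter). Going by these compounds alone, this shows for the first time that this one place alone can move a compound from the limit of the scale to a measured value, with no change to the amide arms. The step itself is a floor and not an exact size, as the value of compound 1 is a limit of the assay and not a number: the limit of > 100000 nM in this assay, at which 1 of the 3 values shown sits.

The compounds shown leave open whether the selenium or the benzyl ring accounts for the step, which a benzylsulfanyl or a methylselanyl group on the same carbon would separate. They also leave open whether the same swap would lower the number when made on the benzothiophene amides of compound 2.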